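Filling the Open Position on the Core of Compound 1

The compounds below may be only part of what the source reports. "The series", "measured", "known", "first", "only" and "open" are said of these compounds alone.

Measured compounds:
compound 1, `Cc1cc(Nc2cc(-c3ccccc3)[nH]n2)n2ncnc2n1`: 21700 nM
compound 2, `Cc1cc(Nc2cc(-c3ccc(Cl)cc3)[nH]n2)n2nc(SCc3ccc(Br)cc3)nc2n1`: 2780 nM

For the measured compounds named here, compound 1 stands at the weak end of these two numbers in a functional assay on MGC-803 cells (Homo sapiens) for inhibition, read by MTT assay, with a stated time of 72 h; on this read-out lower numbers stand for stronger inhibition and higher numbers for weaker inhibition; compound 2 gives a clearly lower value in this assay, but the two compounds differ in more than one place, so their values show only that compound 2 is the stronger inhibitor. Compound 3, `Cc1cc(Nc2cc(-c3ccccc3)[nH]n2)n2nc(SCc3nc4ccccc4[nH]3)nc2n1`, keeps the core of compound 1 and carries a single change: ((1H-benzimidazol-2-yl)methyl)sulfanyl in place of hydrogen on an aromatic carbon. Going by the values given here, no step between measured compounds isolates such an addition, so the size of its effect is open. Compound 3 is nevertheless expected to inhibit more strongly than compound 1 because compound 2, which also carries a sulfanyl group on that carbon, gives 2780 nM. The expected step is a 3.3-fold lower number from compound 1 to compound 3 (0.52 log units; beyond the scatter), beyond the scatter but modest. The estimate for compound 3 is 6500 nM, in a range from 2000 nM to 20000 nM.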

Compound 3, half-maximal inhibitory concentration: 1790 nM
Compound 3: the middle estimate sits 3.6-fold (0.56 log units) above what was measured; measured number below the stated range.
By their numbers in this assay, from the lowest: compounds 3 and 2 (each within the scatter of the next); then compound 1.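

In this assay, for the compounds shown here, ((1H-benzimidazol-2-yl)methyl)sulfanyl in place of hydrogen gives a 12-fold lower number from compound 1 to compound 3 (1.08 log units; beyond the scatter) and so provides the first single-change step at this position. The aromatic carbon between two ring nitrogen atoms, open in compound 1, thus accepts a group of 11 heavy atoms with a large gain in inhibition, which the comparison of compound 1 with compound 2 could not show, as those two differ in more than one place. No measurement at hand accounts for the size of this step.

From the compounds shown here alone, whether the gain belongs to the 1H-benzimidazol-2-yl part or to the sulfanyl link stays open, and so does what a smaller methylsulfanyl group or an amine on this carbon would give. Also open, going by these compounds, is whether a chlorine on the phenyl ring of compound 3 would change its inhibition.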